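A few compounds are considered here, and "the series" means these few. Any claim that something is new, unique, unknown or untested is made for them only; others in the source may bear on it.

Three closely related compounds have been measured in an ADME assay (Rattus norvegicus, strain Han-wistar) for pharmacokinetics, at a dose of 1.5 umol/kg by the intravenous route; a lower number here means that more of the compound stays in the plasma, a higher number that more of the compound sits outside the plasma. Compound 1 `CC(C)n1cc(-c2ccnc3[nH]c(C4CCN(CC(=O)N5CCCC5)CC4)cc23)ccc1=O` gives 3.9 L/kg, compound 2 `CC(C)n1nc(-c2ccnc3[nH]c(C4CCN(CC(=O)N(C)C)CC4)cc23)ccc1=O` gives 2.9 L/kg, and compound 3 `CC(C)n1cc(-c2ccnc3[nH]c(C4CCN(Cc5cccs5)CC4)cc23)ccc1=O` gives 1.6 L/kg. Compound 3 lies within the usual scatter of compound 2, so no order can be read between those two. Its number is clearly lower than that of compound 1, however, and the measured step is a 2.4-fold lower number from compound 1 to compound 3 (0.39 log units; beyond the scatter).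

The next compound to follow is compound 4 `CC(C)n1cc(-c2ccnc3[nH]c(C4CCN(CC(=O)N(C)C)CC4)cc23)ccc1=O`. It carries dimethylcarbamoyl in place of thiophen-2-yl on a saturated chain carbon bound to an amine nitrogen in a ring.

Among the compounds with values here, the one measured step that bears on this change is a 2.4-fold lower number from compound 1 to compound 3 (0.39 log units; beyond the scatter), which replaced an amide-bearing group, (pyrrolidin-1-yl)carbonyl, with thiophen-2-yl at the same place. Compound 4 runs the other way, from thiophen-2-yl back to an amide-bearing group, so a modest move to a higher number in this assay is expected, of about the same size. Compound 2 carries dimethylcarbamoyl on a different core and gives 2.9 L/kg, which fits that expectation without proving it.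

The expected step is a 2.1-fold higher number from compound 3 to compound 4 (0.31 log units; beyond the scatter). Compound 4 is estimated at 3.3 L/kg, with an expected range from 2 L/kg to 5.5 L/kg.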

Compound 4, volume of distribution: 5.9 L/kg
Compound 4: the middle estimate sits 1.8-fold (0.25 log units) below what was measured, outside the stated range (above it).
By their numbers in this assay, from the lowest: compounds 3, 2, 1 and 4 (each within the scatter of the next, the first and the last beyond it).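

In this assay, the direct swap on the shared core, dimethylcarbamoyl in place of thiophen-2-yl on a saturated chain carbon bound to an amine nitrogen in a ring, gives a 3.7-fold higher number from compound 3 to compound 4 (0.57 log units; beyond the scatter) and so measures this change without a difference in the amide to blur it. The amide's own side group makes no readable difference here, since dimethylamino in place of pyrrolidin-1-yl on the carbonyl carbon gives a 1.5-fold higher number from compound 1 to compound 4 (0.18 log units; within the scatter) and leaves the two amide-bearing compounds on this core together, whereas the aromatic group on the core does matter: going from the group with 2 hetero atoms in its ring to the one with 1 gives a 2.0-fold higher number from compound 2 to compound 4 (0.31 log units; beyond the scatter) even though the dimethylcarbamoyl stays the same. Nothing shown here explains why the amide-bearing compounds give the higher numbers.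

Thiophen-2-yl is the only group without an amide at this place, so it remains open whether the lower number belongs to that ring alone or would also appear with a phenyl ring or a plain alkyl chain. From the compounds shown here alone, how a carboxylic acid or a primary amide would behave at the same carbon also remains open.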